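A few compounds are considered here, and "the series" means these few. Any claim that something is new, unique, unknown or untested is made for them only; others in the source may bear on it.

Measured so far in a functional assay on CHO-TAX 5-6 cells (Cricetulus griseus) for antiproliferative activity, read by sulforhodamine B assay, with a stated time of 48 h; a lower number here means a stronger inhibitor, a higher number a weaker inhibitor:
- compound 1 `COc1cc(NS(=O)(=O)c2ccc(N3CCNC3=O)cc2)cc(OC)c1OC`: 170 nM
- compound 2 `Cc1cc(C)cc(NS(=O)(=O)c2ccc(N3CCNC3=O)cc2)c1`: 120 nM
- compound 3 `Cc1cccc(NS(=O)(=O)c2ccc(N3CCNC3=O)cc2)c1`: 150 nM

Compound 1 gives the highest of the three numbers, yet its gaps to compound 3 and to compound 2 both lie within the scatter, so no order among them can be claimed. Compound 4 `COc1cc(NS(=O)(=O)c2ccc(N3CCNC3=O)cc2)cc(OC)c1` is derived from compound 1 by the change (hydrogen in place of methoxy on an aromatic carbon). Among the measured compounds shown here, the only measured step that resembles it is a 1.3-fold higher number from compound 2 to compound 3 (0.10 log units; within the scatter), which removed a smaller group from the same kind of position and stayed within the scatter. On that basis the change to compound 4 is expected to produce no step beyond the scatter, that is no change at the digits printed from compound 1 to compound 4 (within the scatter). Compound 4 is therefore estimated at 170 nM, with a range from 80 nM to 360 nM.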

Compound 4, half-maximal inhibitory concentration: 220 nM
For compound 4 the middle estimate is 1.3-fold (0.11 log units) below the measured one; measured number inside the range.
By their numbers in this assay, from the lowest: compounds 2, 3, 1 and 4 (each within the scatter of the next).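

In this assay, hydrogen in place of the methoxy para to a large group gives a 1.3-fold higher number from compound 1 to compound 4 (0.11 log units; within the scatter), so the number does not move beyond the scatter when this methoxy is lost. Together with a 1.3-fold higher number from compound 2 to compound 3 (0.10 log units; within the scatter), this makes a second removal of a group from an aromatic carbon that stays within the scatter, here a methoxy rather than a methyl. Nothing available offers a reason for this result.

From the compounds shown here alone, it remains open whether an amine, a carboxylic acid or a longer alkoxy chain at this position would give a step beyond the scatter.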